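The source may hold more compounds than are shown below. What is called first, only, known or untested is meant among the compounds shown, and "the series" means these compounds.

Of the compounds shown here, two built on the shared core have been measured so far. Compound 1 `Oc1cc(C(F)(F)F)ccc1-c1nc(-c2ccccc2O)n(-c2ccc(Br)cc2)n1` gives 89.8% in a functional assay on PC-12 cells (Rattus norvegicus) for cytotoxicity, read by MTT assay, with stated times of 2 h and 24 h, tested at 5 uM; a lower number here means a weaker effect, a higher number a stronger effect of the compound at the concentration tested. Compound 2 `N#Cc1ccc(-n2nc(-c3ccc(C(F)(F)F)cc3O)nc2-c2ccccc2O)cc1` differs from compound 1 only by a cyano in place of bromo on an aromatic carbon. In this assay compound 2 gives 86.8%. Among the compounds with values here, the step of a number 3 percentage points lower from compound 1 to compound 2 (within the scatter) is within the scatter, so the two numbers cannot be told apart, and compound 2 stands level with compound 1 on the only pair of numbers available.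

Compound 3 `Oc1cc(C(F)(F)F)ccc1-c1nc(-c2ccccc2O)n(-c2ccccc2Cl)n1` has not yet been measured. It differs from compound 2 as follows: 2-chlorophenyl in place of 4-cyanophenyl on an aromatic nitrogen. Within the data shown here, the single measured step, a number 3 percentage points lower from compound 1 to compound 2 (within the scatter), also changes the substituent carried on that aromatic nitrogen, and it produced nothing beyond the scatter. Among the measured compounds shown here, the change to compound 3 exchanges the whole 4-cyanophenyl for a 2-chlorophenyl, which is a bigger change than anything measured, so no step of known size bears on it directly.

For the measured compounds named here, with only one flat step as guidance, compound 3 is expected to give about 82%, within a range of 60% to 95%. The expected step of a number 4.8 percentage points lower from compound 2 to compound 3 (within the scatter) is therefore estimated to stay within the scatter or fall only slightly.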

Compound 3, a percentage reported as activity, at one concentration (the size of the read-out at that concentration, not a potency): 90.6%
The estimate for compound 3 lay 8.6 percentage points below the measured number, within the range that was stated.
By their numbers in this assay, from the lowest: compounds 2, 1 and 3 (each within the scatter of the next).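

In this assay, the substituent on the aromatic nitrogen has now been changed to a 2-chlorophenyl, and this gives a number 3.8 percentage points higher from compound 2 to compound 3 (within the scatter) and a number 0.8 percentage points higher from compound 1 to compound 3 (within the scatter), so the three compounds cannot be told apart. The earlier pair differed only in the group carried at the 4 position of the phenyl ring, whereas compound 3 has its chlorine at the 2 position and has no nitrile, so the flat picture now covers a second substitution position on this ring, though only across these three compounds. Nothing available explains why the read-out stays level across these changes.

On these data alone, what a phenyl ring carrying an amine or a carboxylic acid would do on this nitrogen stays open, as does the effect of replacing the whole ring with a short alkyl chain. The hydroxyl groups and the trifluoromethyl group are the same in all three compounds, so these numbers say nothing about what those groups contribute to the read-out.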